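Methyl for fluoro on the benzothiazole of a porcupine inhibitor

This account rests on a few compounds, and the source may have more. Where it says the series, first, only, none or still open, it means among the compounds named here.

The study measured compounds in an assay on L cells for inhibition of Protein-serine O-palmitoleoyltransferase porcupine (Mus musculus), read by reporter gene assay, with a stated time of 24 h; a lower number here means that less compound is needed, a higher number that more compound is needed for the effect. Compound 1 `O=C(CNC(=O)c1nn(-c2ccccc2)c(=O)c2ccccc12)Nc1nc2ccc(F)cc2s1` gives 470 nM in this assay, the highest of the three numbers recorded. Compound 3 `O=C(CNC(=O)c1nn(-c2ccc(F)cc2)c(=O)c2ccccc12)Nc1nc2ccc(Cl)cc2s1` gives 25 nM in this assay, a number beyond the scatter below that of compound 1. Compound 2 `O=C(CSc1nc2c(c(=O)n1-c1ccccc1)SCC2)Nc1ccc(-c2ccco2)cn1`, built on a different core, gives 3.5 nM in this assay, the lowest of the three and furthest from compound 1.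

Compound 4 `Cc1ccc2nc(NC(=O)CNC(=O)c3nn(-c4ccccc4)c(=O)c4ccccc34)sc2c1` has not yet been measured in this assay. It differs from compound 1 in one place: methyl in place of fluoro on an aromatic carbon. Among the measured compounds shown here, no step between measured compounds isolates this change, and compound 3 differs from compound 1 in two places at once, so its value alone cannot be split.

Compound 4 is expected to show a small step, a 1.6-fold lower number from compound 1 to compound 4 (0.19 log units; within the scatter), towards a lower number, at or near the edge of the scatter, in part because compound 3 gives 25 nM with a larger group at the same place. The estimate for compound 4 in this assay is 300 nM, with a range from 90 nM to 1000 nM.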

Compound 4, half-maximal effective concentration: 35 nM
Compound 4: middle estimate off by 8.6-fold (0.93 log units), on the high side; the measured number lies below the stated range.
By their numbers in this assay, from the lowest: compound 2; then compounds 3 and 4 (each within the scatter of the next); then compound 1.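

In this assay, among the compounds shown here, the change from 6-fluoro-1,3-benzothiazol-2-yl to 6-methyl-1,3-benzothiazol-2-yl gives a 13-fold lower number from compound 1 to compound 4 (1.13 log units; beyond the scatter) as the first step that isolates this position, and it shows that this one place on the shared core can by itself move the number well beyond the scatter. Compound 3 could not show this, as it differs from compound 1 in two places at once, whereas here one heavy atom replaces one heavy atom, with the counts of hydrogen-bond donors and acceptors and the net charge unchanged. Nothing measured here explains the size of this step.

The compounds shown leave open how methoxy, an amine or a carboxylic acid at this place would compare with methyl on the core of compound 1. They also leave open what chloro alone contributes at this position, as it appears only alongside a second change.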